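Trimming an Amide Ethyl to Methyl: Expected Solubility

This account rests on a few compounds, and the source may have more. Where it says the series, first, only, none or still open, it means among the compounds named here.

Measured compounds:
Compound 1, `CCNC(=O)c1cc(N)c(Nc2ccc(C#N)cc2)cc1Oc1c(C)cc(/C=C/C#N)cc1C`: 1.08 ug/mL
Compound 2, `Cc1cc(/C=C/C#N)cc(C)c1Oc1cc(Nc2ccc(C#N)cc2)c(N)cc1C(=O)N1CC1`: 1.2 ug/mL

Compound 1 is the lower of the two numbers in a physicochemical assay for solubility, read by HPLC, in phosphate buffer, with a stated time of 4 h, at pH 7.4 (on this read-out lower numbers stand for lower solubility and higher numbers for higher solubility), but its step to compound 2 is a 1.1-fold higher number from compound 1 to compound 2 (0.05 log units; within the scatter), so the two values cannot be told apart. Going by the values given here, that step replaces the ethylamino group on the carbonyl carbon with an aziridine ring and is the only change at the amide that has been measured so far.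

The new compound, compound 3, is `CNC(=O)c1cc(N)c(Nc2ccc(C#N)cc2)cc1Oc1c(C)cc(/C=C/C#N)cc1C`. Its difference from compound 1 is hydrogen in place of methyl on a saturated chain carbon bound to an amide-type nitrogen. The change sits on the same amide as the step from compound 1 to compound 2, so that step is the nearest guide: a small alteration at this amide left this assay essentially unmoved. Removing a single carbon is a smaller alteration than swapping in a ring, so no shift beyond the scatter is expected. The expected step is a 1.2-fold higher number from compound 1 to compound 3 (0.08 log units; within the scatter). The estimate for compound 3 in this assay is therefore 1.3 ug/mL, with a range from 0.6 ug/mL to 2.8 ug/mL.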

Compound 3, solubility: 8.28 ug/mL
Compound 3: the middle estimate sits 6.4-fold (0.80 log units) below what was measured; the measured number lies above the stated range.
By their numbers in this assay, from the lowest: compounds 1 and 2 (each within the scatter of the next); then compound 3.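

At this amide, a very small change can move the number beyond the scatter: in this assay, trimming ethylamino to methylamino gives a 7.7-fold higher number from compound 1 to compound 3 (0.88 log units; beyond the scatter) for the loss of a single carbon. The earlier pair gave no sign of this, since a 1.1-fold higher number from compound 1 to compound 2 (0.05 log units; within the scatter) left ethylamino and aziridin-1-yl reading alike, while methylamino in place of aziridin-1-yl now gives a 6.9-fold higher number from compound 2 to compound 3 (0.84 log units; beyond the scatter) and sets the methylamino amide apart from both. The size of a change at this position, counted in atoms, is therefore a poor guide to the size of the step, and nothing available here explains why this one carbon matters so much.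

Still open, as far as these compounds go, is whether the higher number belongs to the methylamino amide alone or carries on to the unsubstituted amide, which has a second hydrogen on the nitrogen in place of the methyl. Also open, from the compounds shown here alone, is where a longer chain such as propyl, or a hydroxyethyl group on that nitrogen, would fall in this assay and whether either would stay close to compound 1 or to compound 3 in this read-out.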